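Anilide variation on a shared thioacetamide-linked core

This account rests on a few compounds, and the source may have more. Where it says the series, first, only, none or still open, it means among the compounds named here.

Measured so far:
- compound 1, `O=C(CSc1nc(Nc2ccccc2)c2ccccc2n1)Nc1ccccc1F`: 12400 nM
- compound 2, `COc1cccc(NC(=O)CSc2nc(Nc3ccccc3)c3ccccc3n2)c1`: 11600 nM
- compound 3, `O=C(CSc1nc(Nc2ccccc2)c2ccccc2n1)Nc1ccc(C(F)(F)F)cc1`: 10400 nM

All three were read in a functional assay on PC-3 cells (Homo sapiens) for inhibition, read by MTT assay, with a stated time of 72 h; a higher number here means a weaker inhibitor, a lower number a stronger inhibitor. The three numbers lie close together. Compound 2 holds the second highest number of the three; the step of a 1.1-fold lower number from compound 1 to compound 2 (0.03 log units; within the scatter) and the step of a 1.1-fold lower number from compound 2 to compound 3 (0.05 log units; within the scatter) both fall within the scatter, as does the step of a 1.2-fold lower number from compound 1 to compound 3 (0.08 log units; within the scatter). Nothing in the measured set separates the three anilide groups on the amide-type nitrogen from one another.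

The next compound, compound 4, is `CCc1ccc(NC(=O)CSc2nc(Nc3ccccc3)c3ccccc3n2)cc1`. It differs from compound 2 in one place: 4-ethylphenyl in place of 3-methoxyphenyl on an amide-type nitrogen. This is the same kind of exchange that the measured steps cover, a swap of one substituted phenyl for another on the amide-type nitrogen with the rest of the molecule unchanged. Each of those steps stayed within the scatter, so no step beyond the scatter is expected in this assay here either, in neither direction.

Compound 4 is therefore expected to give about 11000 nM in this assay, with a plausible range from 5500 nM to 22000 nM. This expectation amounts to a step of a 1.1-fold lower number from compound 2 to compound 4 (0.02 log units; within the scatter), essentially flat.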

Compound 4, half-maximal inhibitory concentration: 17900 nM
Beside the measured number, compound 4's estimate is 1.6-fold (0.21 log units) below it, within the range that was stated.
By their numbers in this assay, from the lowest: compounds 3, 2, 1 and 4 (each within the scatter of the next).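

Notes on the amide-type nitrogen: in this assay, 4-ethylphenyl brings a substituent of carbon only to this position, and the three new steps, a 1.5-fold higher number from compound 2 to compound 4 (0.19 log units; within the scatter), a 1.7-fold higher number from compound 3 to compound 4 (0.24 log units; within the scatter) and a 1.4-fold higher number from compound 1 to compound 4 (0.16 log units; within the scatter), all stay within the scatter. These steps are larger than the earlier ones among compounds 1, 2 and 3, but their size does not separate compound 4 from any of the other three, so exchanging fluoro, methoxy or trifluoromethyl substitution for ethyl gives no readable structure-activity trend across these four anilides. No accompanying data bear on these differences.

Still open, from the compounds shown here alone, is whether any group on this nitrogen can move the number beyond the scatter, for example a carboxylic acid or a dimethylamino group in place of the ethyl on the aromatic carbon, a longer chain such as hexyl, or a cyclohexyl group in place of the substituted phenyl. Also open, going by these compounds, is whether the flat response holds when the rest of the molecule changes, since the shared core stays the same in all four compounds.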